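Aryl swap on the triazole in the spiro series

This account rests on a few compounds, and the source may have more. Where it says the series, first, only, none or still open, it means among the compounds named here.

Within the data shown here, compound 3 `N#CC1=C(N)Oc2c(N)cc3nc4ccccc4nc3c2C12C(=O)N(Cc1cnnn1-c1ccccc1Cl)c1ccccc12` is the only member of this set with a number in a functional assay on HepG2 cells (Homo sapiens) for antiproliferative activity, read by MTT assay, with a stated time of 48 h; a higher number here means a weaker inhibitor, a lower number a stronger inhibitor: compound 3 gives 33500 nM. For compound 1 `CCOc1ccc(-n2nncc2CN2C(=O)C3(C(C#N)=C(N)Oc4c3c3nc5ccccc5nc3c3ccccc43)c3ccccc32)cc1` the reading in this assay is a limit, > 50000 nM. For compound 2 `Cc1ccc(-n2nncc2CN2C(=O)C3(C(C#N)=C(N)Oc4c3c3nc5ccccc5nc3c3ccccc43)c3ccccc32)cc1C` the reading in this assay is likewise a limit, > 50000 nM. Among the measured compounds shown here, the one single-point step measured, a step that the two limits leave unreadable from compound 1 to compound 2, cannot be sized because both ends sit at the limit of > 50000 nM in this assay, at which 2 of the 3 values shown sit.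

Compound 4 `COc1ccc(-n2nncc2CN2C(=O)C3(C(C#N)=C(N)Oc4c(N)cc5nc6ccccc6nc5c43)c3ccccc32)cc1` differs from compound 3 in one place: 4-methoxyphenyl in place of 2-chlorophenyl on an aromatic nitrogen. For the measured compounds named here, no measured step bears directly on this change; the only other aryl variation on that nitrogen, from compound 1 to compound 2, is unreadable. What the values show is that compound 1, which differs from compound 3 in two places, sits at the limit while compound 3 gives a number. The step of a 1.2-fold higher number from compound 3 to compound 4 (0.08 log units; within the scatter) is therefore expected to be none beyond the scatter, with the limit close by. Compound 4 is estimated at 40000 nM, between 15000 nM and 120000 nM.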

Compound 4, half-maximal inhibitory concentration: > 50000 nM
Compound 4: a limit, no number (the forecaster's own chance of this, stated with the estimate: 45%); middle value at least 1.2-fold (0.09 log units) away from the limit.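

In this assay, among these compounds, placing 4-methoxyphenyl in place of 2-chlorophenyl on the aromatic nitrogen of the triazole gives an at least 1.4-fold higher number from compound 3 to compound 4 (0.17 log units; that floor lies within the scatter), the first step at this position with a readable floor. The reading for compound 4 is a limit, > 50000 nM, and not a number. The other step on this nitrogen cannot be read, and the limit now covers most of the set: the limit of > 50000 nM in this assay, at which 3 of the 4 values shown sit.

Going by these compounds, the true size of the step from 2-chlorophenyl to 4-methoxyphenyl stays open, as its floor lies within the scatter and only one end of it is a number. Also open, on these data alone, is how the core of compound 3 would read with an unsubstituted phenyl on this nitrogen, or with an aryl ring carrying an amine or a carboxylic acid.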